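Replacing Ethoxycarbonyl with Hydroxy on Compound 3

The source may hold more compounds than are shown below. What is called first, only, known or untested is meant among the compounds shown, and "the series" means these compounds.

Compound 3 `CCOC(=O)CCCOc1c2cc([N+](=O)[O-])ccc2nn1Cc1ccccc1` has no number to anchor this comparison. In an ADME assay on Vero cells (Chlorocebus sabaeus) for inhibition, read by fluorescence and resazurin assay, with a stated time of 24 h (a lower number here means that less compound is tolerated, a higher number that more compound is tolerated), compound 3 is recorded as "not determined" (no result reported) in the results. Compound 1 `COC(=O)Cn1c2ccc([N+](=O)[O-])cc2c(=O)n1Cc1ccccc1` is likewise recorded as "not determined" (no result reported) in the results. Among the compounds with values here, the only reported reading for this small group belongs to compound 2 `COC(=O)CCOc1c2cc([N+](=O)[O-])ccc2nn1Cc1ccccc1` at > 300000 nM and it is a limit of the assay, not a number.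

Still to be measured in this assay is compound 4 `O=[N+]([O-])c1ccc2nn(Cc3ccccc3)c(OCCCO)c2c1` with a shorter side group. The change is hydroxy in place of ethoxycarbonyl on a saturated chain carbon, three bonds along the chain from an oxygen on an aromatic ring and it puts hydroxy in place of ethoxycarbonyl on a saturated chain carbon, three bonds along the chain from an oxygen on an aromatic ring.

Within the data shown here, no measured step shows what this swap does. Among the measured compounds shown here, the only guide is the limit of > 300000 nM in this assay, at which 1 of the 3 values shown sits, and on that thin basis no step beyond the usual scatter is expected in this assay in either direction. For compound 4 the estimated value is 300000 nM with an expected range from 120000 nM to 600000 nM in this test.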

Compound 4, half-maximal cytotoxic concentration: > 300000 nM
Compound 4: only a limit was reported (the forecaster's own chance of this, stated with the estimate: 70%); the middle value sits exactly at the limit.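

In this assay compound 4 gives > 300000 nM, a limit and not a number. Compound 2 is also reported only as a limit, so no step can be read between compound 2 and compound 4. As far as these compounds go, what hydroxy in place of ethoxycarbonyl does to compound 3 remains open, as compound 3 has no reported number.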